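Lengthening the Chain of Compound 3

This account rests on a few compounds, and the source may have more. Where it says the series, first, only, none or still open, it means among the compounds named here.

Within the data shown here, in a functional assay on WM164 cells (Homo sapiens) for antiproliferative activity, read by sulforhodamine B assay, with a stated time of 48 h (a lower number here means a stronger inhibitor, a higher number a weaker inhibitor), compound 3 `CCCCCCCCCCCCCCNC(=O)[C@@H]1CSC(c2ccc(NC(C)=O)cc2)N1` gives 600 nM on the numbers so far. Compound 2 `CCCCCCCCCCCCCCNC(=O)[C@@H]1CSC(c2ccc(OC)c(OC)c2)N1` gives 800 nM within the scatter of it, while compound 1 `CCCCCCCCNC(=O)[C@@H]1CSC(c2cc(OC)c(OC)c(OC)c2)N1` gives 19600 nM as a clearly higher number than both. Compound 4 `CCCCCCCCCCCCCCCCCNC(=O)[C@@H]1CSC(c2ccc(NC(C)=O)cc2)N1` differs from compound 3 in one place by propyl in place of hydrogen on a saturated chain carbon, ten or more bonds along the chain from an amide-type nitrogen with propyl in place of hydrogen on a saturated chain carbon, ten or more bonds along the chain from an amide-type nitrogen. Among the measured compounds shown here, the only measured step of a 1.3-fold lower number from compound 2 to compound 3 (0.12 log units; within the scatter) has 4-acetamidophenyl in place of 3,4-dimethoxyphenyl and leaves the chain untouched, so it gives no size for this change, and no step beyond the scatter is expected in this assay on this evidence. Compound 4 is expected at 700 nM within an estimated range of 250 nM to 2000 nM as a best guess. The estimated step of a 1.2-fold higher number from compound 3 to compound 4 (0.07 log units; within the scatter) stays within the scatter.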

Compound 4, half-maximal inhibitory concentration: 2400 nM
Estimate against measurement, compound 4: 3.4-fold (0.54 log units) below; measured number above the stated range.
By their numbers in this assay, from the lowest: compounds 3 and 2 (each within the scatter of the next); then compound 4; then compound 1.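

In this assay the chain position now has a measured step: propyl in place of hydrogen on a saturated chain carbon, ten or more bonds along the chain from an amide-type nitrogen, gives a 4.0-fold higher number from compound 3 to compound 4 (0.60 log units; beyond the scatter) and lies beyond the scatter. Added carbon at this position therefore weakens compound 3 rather than leaving it unchanged. Nothing shown gives a reason for this step.

A single step gives no trend with chain length. On these data alone, whether a longer chain weakens further, or a carboxylic acid or an amine at the chain end behaves differently, stays open.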